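A few compounds are considered here, and "the series" means these few. Any claim that something is new, unique, unknown or untested is made for them only; others in the source may bear on it.

Compound 1 `COc1cc2c(Oc3ccc(NC(=O)c4cc(-c5ccccc5C)ccn4)cc3F)ccnc2cc1OCCCN1CCN(C)CC1` gives 150 nM in a functional assay on NCI-H460 cells (Homo sapiens) for cytotoxicity, read by MTT assay, with a stated time of 72 h; on this read-out lower numbers stand for stronger inhibition and higher numbers for weaker inhibition.
Compound 2 `COc1ccc(-c2ccnc(C(=O)Nc3ccc(Oc4ccnc5cc(OCCCN6CCN(C)CC6)c(OC)cc45)c(F)c3)c2)cc1` gives 370 nM in this assay.

Within the data shown here, compound 2 stands at the higher of the two numbers, and the one measured step separates it from compound 1: a 2.5-fold higher number from compound 1 to compound 2 (0.39 log units; beyond the scatter). Compound 3 `COc1ccc(-c2ccnc(C(=O)Nc3ccc(Oc4ccnc5cc(OCCCN6CCN(C)CC6)c(OC)cc45)c(F)c3)c2)c(OC)c1` differs from compound 2 by methoxy in place of hydrogen on an aromatic carbon. The step of a 2.5-fold higher number from compound 1 to compound 2 (0.39 log units; beyond the scatter) exchanged one whole aryl group for another, so it bears only loosely on this smaller change, and no direction is firmly indicated. Compound 3 is therefore expected to land close to compound 2, perhaps slightly lower, a 1.3-fold lower number from compound 2 to compound 3 (0.12 log units; within the scatter). The estimate for compound 3 is 280 nM, within 110 nM to 700 nM.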

Compound 3, half-maximal inhibitory concentration: 430 nM
Compound 3: middle estimate off by 1.5-fold (0.19 log units), on the low side; measured number inside the range.
By their numbers in this assay, from the lowest: compound 1; then compounds 2 and 3 (each within the scatter of the next).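

Adding a second methoxy group to the 4-methoxyphenyl ring, ortho to a large group, gives a 1.2-fold higher number from compound 2 to compound 3 (0.07 log units; within the scatter) and so leaves the number effectively unchanged. The 2,4-dimethoxyphenyl group nevertheless remains separated from 2-methylphenyl, with a 2.9-fold higher number from compound 1 to compound 3 (0.46 log units; beyond the scatter) for that exchange. Nothing available here accounts for either step.

Going by these compounds, what remains open is whether other groups at this ortho place would behave like methoxy, such as an amine or a carboxylic acid. A longer chain, such as ethoxy or propoxy, is equally untested by these compounds.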